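Lengthening the Ester Chain: From Decyl to Pentadecyl

This account rests on a few compounds, and the source may have more. Where it says the series, first, only, none or still open, it means among the compounds named here.

Compound 1, `CCOC(=O)CCC(=O)N1CCN(CCCOc2cc3c(Nc4ccc(F)c(Cl)c4)ncnc3cc2OC)CC1`: 67.4%
Compound 2, `CCCCOC(=O)CCC(=O)N1CCN(CCCOc2cc3c(Nc4ccc(F)c(Cl)c4)ncnc3cc2OC)CC1`: 79.1%
Compound 3, `CCCCCCCCCCOC(=O)CCC(=O)N1CCN(CCCOc2cc3c(Nc4ccc(F)c(Cl)c4)ncnc3cc2OC)CC1`: 15.5%

In a functional assay on A549 cells (Homo sapiens) for cytotoxicity, read by MTT assay, with a stated time of 24 h, tested at 40 uM (on this read-out lower numbers stand for a stronger effect and higher numbers for a weaker effect at the one concentration tested), compound 3 gives the lowest of the three numbers. The step of a number 51.9 percentage points lower from compound 1 to compound 3 (beyond the scatter) and the step of a number 63.6 percentage points lower from compound 2 to compound 3 (beyond the scatter) both ran in the same direction, whereas the step of a number 11.7 percentage points higher from compound 1 to compound 2 (beyond the scatter) ran the other way, so compound 2 goes against any simple reading that a longer chain always lowers the number. Compound 4, `CCCCCCCCCCCCCCCOC(=O)CCC(=O)N1CCN(CCCOc2cc3c(Nc4ccc(F)c(Cl)c4)ncnc3cc2OC)CC1`, carries the change (pentyl in place of hydrogen on a saturated chain carbon, ten or more bonds along the chain from an oxygen next to a carbonyl group). For the measured compounds named here, no measured step reaches this far along the chain; the two large steps ending at compound 3 are the closest guides, and they point toward the effect being kept rather than lost. Compound 4 is therefore expected to give 17%, within 5% to 45%, an estimated step of a number 1.5 percentage points higher from compound 3 to compound 4 (within the scatter) that lies within the scatter.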

Compound 4, a percentage reported as activity, at one concentration (the size of the read-out at that concentration, not a potency): 85.5%
For compound 4 the middle estimate is 68.5 percentage points below the measured one, and the stated range ends below it.
By their numbers in this assay, from the lowest: compound 3; then compound 1; then compounds 2 and 4 (each within the scatter of the next).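

Pentyl in place of hydrogen on a saturated chain carbon removes the strong effect of the decyl ester in this assay, with a number 70 percentage points higher from compound 3 to compound 4 (beyond the scatter). The pentadecyl ester also stands at a number 6.4 percentage points higher from compound 2 to compound 4 (within the scatter), so among the esters shown the low number belongs to the decyl chain alone, and lengthening does not act in one direction. Nothing available explains this reversal.

The compounds shown leave open whether a dodecyl chain keeps the effect, and so where between decyl and pentadecyl it is lost. They also leave open what a carboxylic acid or an amine in place of the ester chain would do.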